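Removing the methoxy group: a phenyl analogue of compound 2

The compounds below may be only part of what the source reports. "The series", "measured", "known", "first", "only" and "open" are said of these compounds alone.

Compound 2 `COc1cccc(C(O)CCn2nc3c(Br)c(Br)c(Br)c(Br)c3n2)c1` was tested in a functional assay on MCF7 cells (Homo sapiens) for antiproliferative activity, read by MTT assay, with a stated time of 24 h, tested at 50 uM (on this read-out lower numbers stand for a stronger effect and higher numbers for a weaker effect at the one concentration tested), where compound 2 gives 22%. Among the three measured compounds this places compound 2 second highest. Compound 1 `OC(CCn1nc2c(Br)c(Br)c(Br)c(Br)c2n1)c1cccc(Br)c1` gives 14%, and the step of a number 8 percentage points higher from compound 1 to compound 2 (within the scatter) lies within the usual scatter. Compound 3 `C[C@@H](O)CCn1nc2c(Br)c(Br)c(Br)c(Br)c2n1`, which carries a methyl group in place of the aryl ring, gives 102%, a number far beyond the scatter from compound 2.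

Compound 4 `OC(CCn1nc2c(Br)c(Br)c(Br)c(Br)c2n1)c1ccccc1` has not yet been measured in this assay. It differs from compound 2 by hydrogen in place of methoxy on an aromatic carbon. Going by the values given here, the only measured step that bears on this change is the one from compound 1 to compound 2, which exchanged one substituent for another at the same aromatic carbon and stayed within the scatter. Since both measured aryl compounds give low numbers, compound 4 is expected to stay close to compound 2, with a step of a number 2 percentage points lower from compound 2 to compound 4 (within the scatter) that is not beyond the scatter. Compound 4 is therefore estimated at 20%, between 6% and 42%.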

Compound 4, a percentage reported as activity, at one concentration (the size of the read-out at that concentration, not a potency): 28%
For compound 4 the middle estimate is 8 percentage points below the measured one, within the range that was stated.
By their numbers in this assay, from the lowest: compounds 1, 2 and 4 (each within the scatter of the next, the first and the last beyond it); then compound 3.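

In this assay, removing the methoxy group gives a number 6 percentage points higher from compound 2 to compound 4 (within the scatter), so at this aromatic carbon, meta to a large group, the 3-methoxyphenyl and phenyl compounds cannot be told apart. Hydrogen in place of bromo at the same carbon gives a number 14 percentage points higher from compound 1 to compound 4 (beyond the scatter), a modest step and the first among these aryl compounds to lie beyond the scatter, although compound 2 remains within the scatter of both compound 1 and compound 4. No measurement is available that would explain these results.

As far as these compounds go, it remains open how an amine or a carboxylic acid at this aromatic carbon would read in this assay. The compounds shown also leave open whether bromo or methoxy on another carbon of the ring would give similar numbers.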